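This account rests on a few compounds, and the source may have more. Where it says the series, first, only, none or still open, it means among the compounds named here.

Two sulfonamides built on the same core have been measured for antiproliferative activity. Compound 1 `O=C1NCCN1c1ccc(S(=O)(=O)Nc2ccc3[nH]ccc3c2)cc1` gives, in a functional assay on MCF7 cells (Homo sapiens) for antiproliferative activity, read by sulforhodamine B assay, with a stated time of 48 h (a higher number here means a weaker inhibitor, a lower number a stronger inhibitor), a value of 170 nM. Compound 2 `Cc1cc(C)cc(NS(=O)(=O)c2ccc(N3CCNC3=O)cc2)c1` gives 100 nM in this assay. Going by the values given here, of the two numbers, the one for compound 2 is the lower, though the gap to compound 1 falls within the usual scatter of repeated measurements, so the two cannot be told apart with confidence. Compound 3 `COc1cccc(NS(=O)(=O)c2ccc(N3CCNC3=O)cc2)c1` has not yet been measured. It differs from compound 2 in one place: 3-methoxyphenyl in place of 3,5-dimethylphenyl on a sulfonamide nitrogen. Among the compounds with values here, no step between two measured compounds is available to guide the size of this change, so the expectation rests only on the narrow spread of the two known values. The expected step is a 1.5-fold higher number from compound 2 to compound 3 (0.18 log units; within the scatter), small enough to stay within the scatter. Compound 3 is therefore expected to give about 150 nM in this assay, with a range from 60 nM to 400 nM.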

Compound 3, half-maximal inhibitory concentration: 120 nM
Compound 3: middle estimate off by 1.3-fold (0.10 log units), on the high side, within the range that was stated.
By their numbers in this assay, from the lowest: compounds 2, 3 and 1 (each within the scatter of the next).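

With 3-methoxyphenyl in place of 3,5-dimethylphenyl on a sulfonamide nitrogen, this assay shows a 1.2-fold higher number from compound 2 to compound 3 (0.08 log units; within the scatter), so compound 2 and compound 3 cannot be told apart. Going by these compounds alone, this is the first step that can be read at this position: the entering group carries one hydrogen-bond acceptor and the leaving group none, yet this difference comes with no change that stands out from the scatter. No measurement at hand explains this result.

The compounds shown leave open how far this holds: an amine or a carboxylic acid on the ring, or a longer chain in place of the methoxy group, might stay within the scatter of compound 2 or move clearly away from it. They also leave open whether a change elsewhere in the shared core would have a larger effect.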